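A few compounds are considered here, and "the series" means these few. Any claim that something is new, unique, unknown or untested is made for them only; others in the source may bear on it.

Measured compounds: compound 1 is `CC(C)n1cc(C(=O)C(=O)Nc2ccc(C(F)(F)F)nc2)c2ccccc21` and gives > 10000 nM. Compound 2 is `CCn1cc(C(=O)C(=O)Nc2ccncc2)c2ccccc21` and gives > 10000 nM. Compound 3 is `COc1ccc(NC(=O)C(=O)c2cn(C(C)C)c3ncccc23)cn1` and gives 126 nM.

In a functional assay on FaDu cells (Homo sapiens) for cytotoxicity, read by MTT assay, with a stated time of 72 h (on this read-out higher numbers stand for lower toxicity in this test and lower numbers for higher toxicity in this test), compound 1 reaches only a limit of the assay, > 10000 nM, so no number stands for it. Compound 2 likewise reaches only a limit in this assay, > 10000 nM. Going by the values given here, compound 3 is the one compound with a number, giving 126 nM in this assay. Compound 1 therefore stands at the limit of > 10000 nM in this assay, at which 2 of the 3 values shown sit, together with compound 2.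

The unmeasured compound 4, `COc1ccc(NC(=O)C(=O)c2cn(C(C)C)c3ccccc23)cn1`, differs from compound 1 in one place: methoxy in place of trifluoromethyl on an aromatic carbon. Compound 3 also carries a methoxy group at this position, and its value shows that a methoxy-bearing compound can reach a number in this assay. Among the compounds with values here, no measured step between compound 1 and compound 4 exists, so the size of the change is an expectation only: the step of an at least 25-fold lower number from compound 1 to compound 4 (1.39 log units; beyond the scatter) is expected to move toward higher toxicity in this assay, beyond the usual scatter, since compound 1 sits only at a limit. Compound 4 is thus estimated to give 400 nM, within a range from 60 nM to 6000 nM.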

Compound 4, concentration lethal to 50% of the cells: 85 nM
Compound 4: middle estimate off by 4.7-fold (0.67 log units), on the high side; the range from low to high includes it.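

In this assay, methoxy in place of trifluoromethyl on the aromatic carbon next to the ring nitrogen is the first one-place change shown, and it brings an at least 110-fold lower number from compound 1 to compound 4 (2.07 log units; beyond the scatter), toward higher toxicity in this test. This single position is therefore enough to take the read-out from a limit of the assay to a number, with the rest of the structure unchanged. The size of the step is only a bound because compound 1 stands at a limit: the limit of > 10000 nM in this assay, at which 2 of the 4 values shown sit.

Going by these compounds, only these two groups appear at this position, and how an amine, a hydroxyl or a longer chain such as ethoxy would read there remains open. Also open, on these data alone, is whether methoxy itself drives the change or the loss of trifluoromethyl does.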